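Changing the Amide Nitrogen Substituent of Compound 3

The source may report more compounds than this note shows. Statements on the series, on what has been measured and on what is new or still open speak of the compounds shown alone.

In an ADME assay on microsomes from liver (Rattus norvegicus) for metabolic stability (a lower number here means that the compound disappears faster, a higher number that the compound lasts longer), compound 1 `Cc1cccc(NC(=O)c2nn(C)c(-c3ccc(F)cc3F)c2C)n1` gives 1.27 h. Compound 3 `Cc1nc(C(=O)Nc2cccc(F)n2)c(C)n1-c1ccc(F)cc1` gives 1.13 h, which places compound 3 level with compound 1 within the scatter. For compound 2 `Cc1cccc(NC(=O)c2nn(C)c(-c3ccc(C(F)(F)F)cc3)c2C)n1`, this assay returns only a limit, > 5 h. Compound 4 `Cc1nc(C(=O)Nc2ccnc(Cl)n2)c(C)n1-c1ccc(F)cc1` carries 2-chloropyrimidin-4-yl in place of 6-fluoropyridin-2-yl on an amide-type nitrogen. Going by the values given here, no pair of measured compounds differs in a single place, so the data offer no direct guide to the size of this change. The expected step of a 1.1-fold lower number from compound 3 to compound 4 (0.05 log units; within the scatter) is small, stays within the scatter and has no firm direction. For compound 4 the estimated half-life is 1 h, with an expected range of 0.4 h to 2.5 h.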

Compound 4, half-life: 2.75 h
The estimate for compound 4 lay 2.8-fold (0.44 log units) below the measured number; measured number above the stated range.
By their numbers in this assay, from the lowest: compounds 3 and 1 (each within the scatter of the next); then compound 4. At a limit, above all of these: compound 2.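

In this assay the exchange of 6-fluoropyridin-2-yl for 2-chloropyrimidin-4-yl on the amide-type nitrogen gives a 2.4-fold higher number from compound 3 to compound 4 (0.39 log units; beyond the scatter) and so shows that this position can move the half-life beyond the scatter. Going by these compounds alone, this is the first single-place change that can be read here, and its size is modest. Nothing measured here accounts for the rise.

The compounds shown leave open whether the rise follows the extra ring nitrogen or the chlorine, since both change together. They also leave open how a methoxy group in place of the chlorine would fare.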